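A few compounds are considered here, and "the series" means these few. Any claim that something is new, unique, unknown or untested is made for them only; others in the source may bear on it.

Measured in a functional assay on HCT-116 cells (Homo sapiens) for cytotoxicity, read by MTT assay, with a stated time of 72 h; on this read-out higher numbers stand for weaker inhibition and lower numbers for stronger inhibition:
compound 1 `CN1[C@@H]2c3[nH]c4ccccc4c3C[C@H]1[C@H](C#N)N1[C@@H](CN3C(=O)c4ccccc4C3=O)c3[nH]c4ccccc4c3C[C@@H]21` gives 40 nM.
compound 2 `CN1[C@@H]2c3[nH]c4ccccc4c3C[C@H]1[C@H](C#N)N1[C@@H](CNC(=O)c3cccc(C(F)(F)F)c3)c3[nH]c4ccccc4c3C[C@@H]21` gives 630 nM.
compound 3 `CN1[C@@H]2c3[nH]c4ccccc4c3C[C@H]1[C@H](C#N)N1[C@@H](CNC(=O)c3ccc4ccccc4c3)c3[nH]c4ccccc4c3C[C@@H]21` gives 420 nM.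

Compound 3 stands second highest of the three numbers; compound 2 lies nearest, within the scatter, and compound 1 lies furthest, beyond it. Compound 4 `COc1ccc(/C=C/C(=O)NC[C@H]2c3[nH]c4ccccc4c3C[C@H]3[C@H]4c5[nH]c6ccccc6c5C[C@@H]([C@H](C#N)N23)N4C)cc1` carries 2-(4-methoxyphenyl)ethenyl in place of naphthalen-2-yl on a carbonyl carbon. Within the data shown here, the one measured step at the same carbonyl, a 1.5-fold lower number from compound 2 to compound 3 (0.18 log units; within the scatter), was within the scatter. Among the measured compounds shown here, no measured step covers an ethenyl group, and compound 1 differs from compound 3 at another part of the amide, so its gap to compound 3 is only noted. In this assay compound 4 is therefore expected to show a 1.1-fold higher number from compound 3 to compound 4 (0.03 log units; within the scatter), no change beyond the scatter. The estimate for compound 4 is 450 nM, with a range of 180 nM to 1100 nM.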

Compound 4, half-maximal inhibitory concentration: 5060 nM
Compound 4: the middle estimate sits 11-fold (1.05 log units) below what was measured, outside the stated range (above it).
By their numbers in this assay, from the lowest: compound 1; then compounds 3 and 2 (each within the scatter of the next); then compound 4.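

In this assay, among these compounds, the group on the carbonyl carbon proves able to shift the read-out: 2-(4-methoxyphenyl)ethenyl gives a 12-fold higher number from compound 3 to compound 4 (1.08 log units; beyond the scatter) and an 8.0-fold higher number from compound 2 to compound 4 (0.90 log units; beyond the scatter), whereas the only earlier step at this carbonyl, a 1.5-fold lower number from compound 2 to compound 3 (0.18 log units; within the scatter), stayed within the scatter. Among these amides, the read-out therefore does not stay flat across every group placed here. Nothing available explains this shift.

The compounds shown leave open whether the ethenyl link or the methoxy group accounts for the shift. 4-Methoxyphenyl on the carbonyl carbon and 2-phenylethenyl would separate the two.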